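The source may hold more compounds than are shown below. What is called first, only, known or untested is meant among the compounds shown, and "the series" means these compounds.

Measured compounds:
- compound 1 `NC(=O)[C@@H]1CC[C@H](c2ccc(OCc3ccccc3)cc2)N1`: in an assay on HEK293 cells for inhibition of sodium channel protein type 3 subunit alpha (Homo sapiens), read by electrophysiology, with a stated time of 3.5 min (on this read-out higher numbers stand for weaker inhibition and lower numbers for stronger inhibition), compound 1 gives > 63000 nM, which is a limit of the assay and not a number.
- compound 2 `NC(=O)[C@@H]1CC[C@H](c2ccc(Oc3ccccc3)cc2)N1`: in this assay compound 2 gives 100000 nM.

On the numbers shown, compound 1 therefore stands only as a limit, recorded as the limit of > 63000 nM in this assay, at which 1 of the 2 values shown sits. For the measured compounds named here, the single measured step, a step that the limit leaves unreadable from compound 1 to compound 2, is one that this limit leaves unreadable, so it offers neither a size nor a direction. Compound 3 `C[C@@H](Oc1ccc([C@H]2CC[C@@H](C(N)=O)N2)cc1)c1ccccc1` differs from compound 1 by methyl in place of hydrogen on a saturated chain carbon bound to an aromatic carbon and an oxygen on an aromatic ring. Going by the values given here, no measured step involves a change of this kind, and the only step available, a step that the limit leaves unreadable from compound 1 to compound 2, cannot be read. With both measured compounds showing only very weak inhibition in this assay, no shift beyond the scatter is expected, and the step that the limit leaves unreadable from compound 1 to compound 3 is estimated to be small. Compound 3 is estimated at 70000 nM, within 30000 nM to 150000 nM, quite possibly reported again only as a limit.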

Compound 3, half-maximal inhibitory concentration: 31600 nM
Beside the measured number, compound 3's estimate is 2.2-fold (0.35 log units) above it, within the range that was stated.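

For the compounds shown here, the methyl in place of hydrogen on a saturated chain carbon bound to an aromatic carbon and an oxygen on an aromatic ring gives the first step in this small set that can be read in this assay: an at least 1.9-fold lower number from compound 1 to compound 3 (0.29 log units; that floor lies within the scatter). The step therefore points towards stronger inhibition, but its floor does not clear the usual scatter of repeated measurements, so this small change is not yet shown to matter. Going by these compounds, its true size stays unknown because compound 1 is recorded only as a limit of the assay: the limit of > 63000 nM in this assay, at which 1 of the 3 values shown sits.

On these data alone, it remains open whether an ethyl group or a second methyl on this same carbon would move the number further, and how the opposite spatial arrangement of the methyl would read. Also open, as far as these compounds go, is what a carboxylic acid in place of the amide on the shared core would do in this assay.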